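Swapping methyl for phenyl on the amide carbonyl

The source may hold more compounds than are shown below. What is called first, only, known or untested is meant among the compounds shown, and "the series" means these compounds.

- compound 1 `COc1ccc(S(=O)(=O)N2CCc3cccc(NC(=O)c4ccc([N+](=O)[O-])cc4)c32)cc1`: 95 nM
- compound 2 `COc1ccc(S(=O)(=O)N2CCc3cccc(NC(C)=O)c32)cc1`: 90 nM

In a functional assay on KB cells (Homo sapiens) for cytotoxicity (a lower number here means a stronger inhibitor, a higher number a weaker inhibitor), the two measured compounds stand level, so compound 2 cannot be separated from compound 1 on these numbers. The next compound, compound 3 `COc1ccc(S(=O)(=O)N2CCc3cccc(NC(=O)c4ccccc4)c32)cc1`, keeps the shared core and alters only the group on the amide carbonyl of compound 2: phenyl in place of methyl on a carbonyl carbon. In words, this puts phenyl in place of methyl on a carbonyl carbon.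

For the measured compounds named here, one measured step bears on this change, at the same carbonyl carbon: methyl in place of 4-nitrophenyl, a 1.1-fold lower number from compound 1 to compound 2 (0.02 log units; within the scatter). Going by the values given here, no compound with plain phenyl has been measured yet. Among the compounds with values here, with only that small step as a guide, no change beyond the scatter is expected in this assay. The expected step is a 1.1-fold lower number from compound 2 to compound 3 (0.05 log units; within the scatter). For compound 3 the estimated value is 80 nM, with an expected range from 30 nM to 220 nM.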

Compound 3, half-maximal inhibitory concentration: 180 nM
Compound 3: middle estimate off by 2.3-fold (0.35 log units), on the low side; the measured number falls inside the stated range.
By their numbers in this assay, from the lowest: compounds 2, 1 and 3 (each within the scatter of the next).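

In this assay, the amide carbonyl carbon now carries methyl, phenyl or 4-nitrophenyl, and neither new change moves the number beyond the scatter: phenyl in place of methyl (a 2.0-fold higher number from compound 2 to compound 3 (0.30 log units; within the scatter)) and hydrogen in place of nitro on an aromatic carbon (a 1.9-fold higher number from compound 1 to compound 3 (0.28 log units; within the scatter)). This place on the shared core therefore holds either a single carbon or a six-membered aromatic ring, with or without the nitro group, and these numbers do not separate compound 1, compound 2 and compound 3. No measurement at hand accounts for how close these numbers lie.

From the compounds shown here alone, it remains open what a longer chain, such as propyl or butyl, would do on this carbonyl carbon. Going by these compounds, it is equally open whether an amine or a carboxylic acid on the phenyl ring would leave the number within the scatter.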